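Amide nitrogen substituent steps in the series

The compounds below may be only part of what the source reports. "The series", "measured", "known", "first", "only" and "open" are said of these compounds alone.

Measured compounds:
compound 1 `CNC(=O)c1cc(Oc2cccc(NC(=S)Nc3cccc(C(F)(F)F)c3)c2)ccn1` — in a functional assay on MDA-MB-231 cells (Homo sapiens) for cytotoxicity, read by MTT assay, with a stated time of 48 h (a lower number here means a stronger inhibitor, a higher number a weaker inhibitor), compound 1 reports only a limit, > 100000 nM.
compound 2 `CCNC(=O)c1cc(Oc2cccc(NC(=S)Nc3cccc(C(F)(F)F)c3)c2)ccn1` — in this assay compound 2 gives 53100 nM.

Compound 2 carries the only number shown in this assay; the other result is a limit (the limit of > 100000 nM in this assay, at which 1 of the 2 values shown sits). Within the data shown here, the one measured step, an at least 1.8-fold lower number from compound 1 to compound 2 (0.27 log units; that floor lies within the scatter), has a floor within the scatter, so it sets no firm direction. Compound 3 `O=C(NC1CC1)c1cc(Oc2cccc(NC(=S)Nc3cccc(C(F)(F)F)c3)c2)ccn1` differs from compound 2 by cyclopropyl in place of ethyl on an amide-type nitrogen. Among the measured compounds shown here, that measured step is the only guide, and it gives no reason to expect a change beyond the scatter. Compound 3 is therefore expected to sit near compound 2, at an estimated 40000 nM (range 15000 nM to 100000 nM). The expected step is a 1.3-fold lower number from compound 2 to compound 3 (0.12 log units; within the scatter).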

Compound 3, half-maximal inhibitory concentration: 34800 nM
Compound 3: middle estimate off by 1.1-fold (0.06 log units), on the high side, and the stated range covers the measured number.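

In this assay, cyclopropyl in place of ethyl on the amide-type nitrogen gives a 1.5-fold lower number from compound 2 to compound 3 (0.18 log units; within the scatter), so the three-membered ring keeps the number level with ethyl. Against methyl, the series now has its first step that clears the scatter, an at least 2.8-fold lower number from compound 1 to compound 3 (0.45 log units; beyond the scatter). That step remains only a floor because compound 1 reports a limit: the limit of > 100000 nM in this assay, at which 1 of the 3 values shown sits.

From the compounds shown here alone, whether a longer chain such as butyl, or a larger ring such as cyclohexyl, on this nitrogen would move the number clearly past compound 3 stays open. Going by these compounds, the primary amide, with hydrogen alone on this nitrogen, also stays open.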